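The compounds below may be only part of what the source reports. "The series", "measured", "known", "first", "only" and "open" are said of these compounds alone.

Measured compounds in a functional assay on MDA-MB-435 cells (Homo sapiens) for cytotoxicity, read by MTT assay, with a stated time of 72 h; a lower number here means a stronger inhibitor, a higher number a weaker inhibitor:
compound 1 `CC(C)(C)OC(=O)N1CCN(c2c(C(=O)NCc3ccc(F)cc3)nc(Br)c3cccnc23)CC1`: 10000 nM
compound 2 `N[C@H]1CC[C@H](Nc2c(C(=O)NCc3ccc(Cl)cc3Cl)nc(Br)c3cccnc23)CC1`: 5800 nM
compound 3 `O=C(NCc1ccc(F)cc1)c1nc(Br)c2cccnc2c1NCc1ccccc1`: > 20000 nM

Compound 2 has the lowest of the two numbers shown; compound 1 lies within the scatter of it, so the two are not separated. The value of compound 3 is a limit and not a number: compound 3 sits at the limit of > 20000 nM in this assay, at which 1 of the 3 values shown sits. Compound 4 `N[C@H]1CC[C@H](Nc2c(C(=O)Nc3ccccc3)nc(Br)c3cccnc23)CC1` is not yet measured in this assay. It differs from compound 2 in one place: phenyl in place of 2,4-dichlorobenzyl on an amide-type nitrogen, read one bond further out, (2,4-dichlorobenzyl)amino becomes anilino. Within the data shown here, no step between measured compounds calibrates this change; the expectation is a moderate step toward a higher number. Compound 4 is estimated at 9000 nM, with a range from 3000 nM to 20000 nM. The expected step of a 1.6-fold higher number from compound 2 to compound 4 (0.19 log units; within the scatter) could also end at the limit.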

Compound 4, half-maximal inhibitory concentration: 1000 nM
The estimate for compound 4 lay 9.0-fold (0.95 log units) above the measured number, outside the stated range (below it).
By their numbers in this assay, from the lowest: compound 4; then compounds 2 and 1 (each within the scatter of the next). At a limit, above all of these: compound 3.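

In this assay, the group on the amide-type nitrogen proves able to shift the number: phenyl in place of 2,4-dichlorobenzyl gives a 5.8-fold lower number from compound 2 to compound 4 (0.76 log units; beyond the scatter). Compound 1, compound 2 and compound 3 offered no reading of this position alone, as none of them differ in one place only. Nothing measured here speaks to what lies behind this step.

The change removes both chlorine atoms and the benzyl carbon together, and these remain unseparated. As far as these compounds go, whether an unsubstituted benzyl or a 4-chlorophenyl group would sit with compound 2 or with compound 4 stays open.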